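The compounds below may be only part of what the source reports. "The series", "measured", "known", "first", "only" and "open" are said of these compounds alone.

Of the compounds shown here, three sharing one core have been measured in an assay on isolated protein for inhibition of Rho-associated protein kinase 2 (Homo sapiens), read by a luciferase reporter; on this read-out higher numbers stand for weaker inhibition and lower numbers for stronger inhibition. Compound 1 `NCC(=O)Nc1cc2cc[nH]c(=O)c2cc1Cl` gives 120 nM, compound 2 `O=C(Nc1cc2cc[nH]c(=O)c2cc1Cl)C1CNCC1c1ccccn1` gives 14 nM, and compound 3 `O=C(Nc1cc2cc[nH]c(=O)c2cc1Cl)C1CNCCC1c1ccccc1` gives 6 nM. Compound 2 thus holds the second highest of the three numbers: compound 3 sits below it beyond the scatter, and compound 1 sits further above it, also beyond the scatter. Compound 4 `CC(C)c1cccc(C2CNCC2C(=O)Nc2cc3cc[nH]c(=O)c3cc2Cl)c1` has not been measured; it differs from compound 2 in one place, (3-isopropylphenyl in place of pyridin-2-yl on a saturated ring carbon), that is, 3-isopropylphenyl in place of pyridin-2-yl on a saturated ring carbon. Going by the values given here, no measured pair shows this exact change. Compound 3, whose aryl ring is carbon only, gives 6 nM in this assay, which guides the expectation. For compound 4 a small downward step a 1.8-fold lower number from compound 2 to compound 4 (0.24 log units; within the scatter) is expected. The estimate for compound 4 is 8 nM, with a range from 3 nM to 30 nM.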

Compound 4, half-maximal inhibitory concentration: 6 nM
Compound 4: the middle estimate sits 1.3-fold (0.12 log units) above what was measured; low and high end bracket the measured number.
By their numbers in this assay, from the lowest: compounds 3 and 4 (each within the scatter of the next); then compound 2; then compound 1.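

On the saturated ring carbon, two ring bonds from the ring nitrogen, the larger 3-isopropylphenyl is accepted in place of pyridin-2-yl: the change gives a modest gain, with a 2.3-fold lower number from compound 2 to compound 4 (0.37 log units; beyond the scatter) as the step. The nitrogen of pyridin-2-yl, with its hydrogen-bond acceptor, is therefore not needed at this position to reach a low number, although the ring atom and the isopropyl group change together. Nothing available accounts for the step.

The compounds shown do not separate the effect of the ring nitrogen from that of the isopropyl group, as unsubstituted phenyl does not appear on this five-membered ring. On these data alone, whether an amine or a carboxylic acid in place of the isopropyl group would be tolerated also remains open.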